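A few compounds are considered here, and "the series" means these few. Any claim that something is new, unique, unknown or untested is made for them only; others in the source may bear on it.

Measured compounds:
- compound 1, `COc1ccc(C(=O)Nc2ccccc2C)cc1OC1CCCC1`: in an assay on isolated protein for inhibition of phosphodiesterase 4A (Sus scrofa) (a higher number here means a weaker inhibitor, a lower number a stronger inhibitor), compound 1 gives 300 nM.
- compound 2, `COc1ccc(C(=O)Nc2ccccc2F)cc1OC1CCCC1`: in this assay compound 2 gives 10700 nM.
- compound 3, `COc1ccc(C(=O)Nc2cccc(Cl)c2Cl)cc1OC1CCCC1`: in this assay compound 3 reaches only > 200000 nM, which is a limit of the assay and not a number.

Compound 3 thus stands at the weak end of the three shown, at the limit (the limit of > 200000 nM in this assay, at which 1 of the 3 values shown sits). The next compound is compound 4, `COc1ccc(C(=O)Nc2c(C)cccc2Cl)cc1OC1CCCC1`, which differs from compound 3 in one place: 2-chloro-6-methylphenyl in place of 2,3-dichlorophenyl on an amide-type nitrogen. The change brings back the methyl that compound 1 carries on the phenyl of the amide nitrogen, while one chloro is kept.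

Among the measured compounds shown here, the steps that bear on it are all large. Replacing methyl by fluoro gave a 36-fold higher number from compound 1 to compound 2 (1.55 log units; beyond the scatter). Going from the 2-methylphenyl of compound 1 to the 2,3-dichlorophenyl of compound 3 gave an at least 660-fold higher number from compound 1 to compound 3 (2.82 log units; beyond the scatter), and from the 2-fluorophenyl of compound 2 to the same 2,3-dichlorophenyl gave an at least 18-fold higher number from compound 2 to compound 3 (1.27 log units; beyond the scatter). The methyl on that phenyl goes with the lowest number shown, the 2,3-dichloro pattern with a limit; compound 4 carries both a methyl and a chloro, so a step in this assay back toward lower numbers than compound 3 is expected, though not all the way to compound 1.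

For compound 4 in this assay an estimated 12000 nM is expected, within 1500 nM to 120000 nM, an expected step of an at least 16-fold lower number from compound 3 to compound 4 (1.22 log units; beyond the scatter).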

Compound 4, half-maximal inhibitory concentration: 100 nM
Estimate against measurement, compound 4: 120-fold (2.08 log units) above; the whole stated range lies above it.
By their numbers in this assay, from the lowest: compound 4; then compound 1; then compound 2. At a limit, above all of these: compound 3.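

In this assay, chloro in place of hydrogen on an aromatic carbon of the 2-methylphenyl gave a 3.0-fold lower number from compound 1 to compound 4 (0.48 log units; beyond the scatter), so a chloro on this phenyl is not tied to a high number, as compound 3 alone might have suggested, and the number moves down modestly once the methyl is present. The 2-chloro-6-methylphenyl on the amide-type nitrogen also gave an at least 2000-fold lower number from compound 3 to compound 4 (3.30 log units; beyond the scatter) and a 110-fold lower number from compound 2 to compound 4 (2.03 log units; beyond the scatter), so among the four compounds the two that carry a methyl on this phenyl, compound 1 and compound 4, hold the two lowest numbers, with no compound shown going against this. Compound 3 stands at a limit and not at a number, so the first of those two steps is only a bound: the limit of > 200000 nM in this assay, at which 1 of the 4 values shown sits.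

Still open, from the compounds shown here alone, is whether the methyl and the chloro of compound 4 are each needed, since only one substitution pattern carries both. A bromo or a nitrile in place of its chloro, an ethyl in place of its methyl, or an amine on the same phenyl would each test how far this position reaches in this assay.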